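The source may hold more compounds than are shown below. What is called first, only, known or untested is meant among the compounds shown, and "the series" means these compounds.

Compound 3 `COc1cc(NC(C)CCCNCC2CCC3(CC2)OOC2(OO3)C3CC4CC(C3)CC2C4)c2ncccc2c1-c1ccc(Cl)cc1` carries a 4-chlorophenyl on the shared core. Among the measured compounds shown here, in an ADME assay on Caco-2 cells (Homo sapiens) for cytotoxicity, read by neutral red uptake, with a stated time of 72 h (on this read-out lower numbers stand for higher toxicity in this test and higher numbers for lower toxicity in this test), compound 3 gives 13200 nM, the only plain number among the three entries. Compound 1 `COc1cc(NC(C)CCCNC(=O)C2CCC3(CC2)OOC2(OO3)C3CC4CC(C3)CC2C4)c2ncccc2c1-c1ccsc1` reaches only a limit of the assay; in this assay compound 1 gives > 50000 nM. For compound 1 this reading is the limit of > 50000 nM in this assay, at which 1 of the 3 values shown sits. For compound 2 `COc1cc(NC(C)CCCNC(=O)C2CCC3(CC2)OOC2(OO3)C3CC4CC(C3)CC2C4)c2ncccc2c1Br` this assay gives "not determined" (no result reported). Compound 4 `COc1cc(NC(C)CCCNCC2CCC3(CC2)OOC2(OO3)C3CC4CC(C3)CC2C4)c2ncccc2c1-c1ccc(C)cc1` differs from compound 3 in one place: methyl in place of chloro on an aromatic carbon. For the measured compounds named here, no pair of measured compounds differing in a single place is available, so the size of such a step is not anchored by any measured comparison. An exchange of this kind is expected to move the half-maximal cytotoxic concentration in this assay by no more than the usual scatter, in no particular direction, so the expected step of a 1.1-fold higher number from compound 3 to compound 4 (0.06 log units; within the scatter) is small. Compound 4 is therefore estimated at 15000 nM, with a range from 5000 nM to 45000 nM.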

Compound 4, half-maximal cytotoxic concentration: 11700 nM
For compound 4 the middle estimate is 1.3-fold (0.11 log units) above the measured one; low and high end bracket the measured number.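

In this assay, among the compounds shown here, the exchange of 4-chlorophenyl for 4-methylphenyl provides the first measured comparison of compounds differing in one place (a 1.1-fold lower number from compound 3 to compound 4 (0.05 log units; within the scatter)). For the compounds shown here, at this position, on an aromatic carbon of a six-membered aromatic ring of carbon only and para to a large group, chloro and methyl therefore cannot be told apart in this test, a measured anchor that the earlier compounds could not supply. Nothing given here bears on a cause for this step.

From the compounds shown here alone, whether an amine, a carboxylic acid or a longer chain at this position would move the number beyond the scatter remains open. Going by these compounds, compound 1 differs from compound 3 in more than one place, so the separate contributions of those differences also remain open.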